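This account rests on a few compounds, and the source may have more. Where it says the series, first, only, none or still open, it means among the compounds named here.

Working notes on the series. In a functional assay for antagonist activity at transient receptor potential cation channel subfamily V member 1 (Homo sapiens), read by FLIPR (a higher number here means a weaker inhibitor, a lower number a stronger inhibitor), two compounds have been measured so far. Compound 1 `N#Cc1ccc(NC(=O)c2ccc(-c3ncccc3C(F)(F)F)cc2)cc1` gives 417 nM in this assay. Compound 2 `CCCOc1cccnc1-c1ccc(C(=O)Nc2ccc(C(C)(C)C)cc2)cc1` gives 62 nM in this assay, the lower of the two numbers; the gap between compound 1 and compound 2 is beyond the scatter, so compound 2 stands as the stronger inhibitor of the pair. Compound 1 and compound 2 differ in more than one place, so no single step can be read from them.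

The next compound, compound 3 `CC(C)(C)c1ccc(NC(=O)c2ccc(-c3ncccc3NS(=O)(=O)c3ccccc3)cc2)cc1`, is not yet measured in this assay. It keeps the core of compound 2 and changes one place: (phenylsulfonyl)amino in place of propoxy on an aromatic carbon. The group that enters is a good deal larger than the one that leaves and brings one hydrogen-bond donor where there was none; the position is ortho to a large group and two atoms from the ring nitrogen. Among the measured compounds shown here, no step of this kind is on record, so the expectation rests on compound 2 alone. For compound 3 a step of a 3.2-fold higher number from compound 2 to compound 3 (0.51 log units; beyond the scatter) is expected, a shift toward a weaker inhibitor that would lie beyond the scatter. The estimate for compound 3 in this assay is 200 nM, with a range from 40 nM to 1000 nM.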

Compound 3, half-maximal inhibitory concentration: 91 nM
Beside the measured number, compound 3's estimate is 2.2-fold (0.34 log units) above it; the measured number falls inside the stated range.
By their numbers in this assay, from the lowest: compounds 2 and 3 (each within the scatter of the next); then compound 1.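

In this assay, among the compounds shown here, (phenylsulfonyl)amino in place of propoxy on this aromatic carbon gives a 1.5-fold higher number from compound 2 to compound 3 (0.17 log units; within the scatter), the first step that can be read at this place, ortho to a large group and two atoms from the ring nitrogen. The step shows that the read-out at this place can stay within the scatter across a substantial change: 10 heavy atoms, a six-membered aromatic ring and 1 hydrogen-bond donor enter where 4 heavy atoms, no ring and no donor leave, so compound 2 and compound 3 cannot be separated by this read-out. No measurement at hand bears on why this is so.

Going by these compounds, how the read-out responds to a much smaller group at this place, such as a free amine or a methoxy, or to a methylsulfonylamino, in which a methyl takes the place of the phenyl ring, remains open. Also open, on these data alone, is whether the same step would hold with a nitrile in place of the tert-butyl group on the other side of the amide, since this single step was read with the tert-butyl group present.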